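Piperidine nitrogen substituent and kinetic solubility in this series

The source may hold more compounds than are shown below. What is called first, only, known or untested is meant among the compounds shown, and "the series" means these compounds.

Compound 1 `CCN1CCN(c2ccc3c(c2)oc(=O)n3C(=O)NCCCCc2ccccc2)CC1`: in a physicochemical assay for solubility, read by HPLC, in phosphate buffer, measured as kinetic solubility, with a stated time of 1 h, at pH 7.4, tested at 250 uM (on this read-out higher numbers stand for higher solubility and lower numbers for lower solubility), compound 1 gives < 1000 nM, a limit of the assay.
Compound 2 `CC(C)N1CCC(c2ccc3c(c2)oc(=O)n3C(=O)NCCCCc2ccccc2)CC1`: compound 2 gives 50000 nM.
Compound 3 `CC(C)CN1CCC(c2ccc3c(c2)oc(=O)n3C(=O)NCCCCc2ccccc2)CC1`: compound 3 gives < 1000 nM, again a limit of the assay.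

Compound 3 thus sits at the limit of < 1000 nM in this assay, at which 2 of the 3 values shown sit. Among the compounds with values here, the one measured comparison at the same ring nitrogen is an at least 50-fold lower number from compound 2 to compound 3 (1.69 log units; beyond the scatter). In the other direction, an at least 50-fold higher number from compound 1 to compound 2 (1.69 log units; beyond the scatter). Between the two limits, a step that the two limits leave unreadable from compound 1 to compound 3.

Compound 4 `CC(=O)N1CCC(c2ccc3c(c2)oc(=O)n3C(=O)NCCCCc2ccccc2)CC1` differs from compound 3 by acetyl in place of isobutyl on an amine nitrogen in a ring. Within the data shown here, no measured step puts an acetyl on this amine nitrogen, so the size of the change is open; the step from isopropyl to isobutyl shows that a small change here can move the number by a large amount. For compound 4 the expected step is an at least 5.0-fold higher number from compound 3 to compound 4 (0.69 log units; beyond the scatter), upward from the limit. The estimate for compound 4 is 5000 nM, with a range from 1000 nM to 40000 nM.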

Compound 4, solubility: < 1000 nM
Compound 4 gave a limit, no number (the forecaster's own chance of this, stated with the estimate: 40%); middle value at least 5.0-fold (0.69 log units) from the limit.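

In this assay compound 4 gives < 1000 nM, a limit of the assay and not a number. Isopropyl remains the only group on this amine nitrogen with a readable value, and acetyl gives an at least 50-fold lower number from compound 2 to compound 4 (1.69 log units; beyond the scatter). The steps from compound 3 and from compound 1 to compound 4 cannot be read, as both ends are limits: the limit of < 1000 nM in this assay, at which 3 of the 4 values shown sit.

From the compounds shown here alone, how acetyl and isobutyl stand relative to each other stays open, since limits cannot be ordered. Going by these compounds, whether a methyl or a cyclopropyl on this nitrogen would give a readable value also stays open.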